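Branching the Amine-Bearing Carbon: From Isobutyl to Tert-Butyl

The source may hold more compounds than are shown below. What is called first, only, known or untested is meant among the compounds shown, and "the series" means these compounds.

Measured compounds:
compound 1 `CC(C)C[C@H](N)CN(C(=O)[C@@H]1C[C@H]1c1ccccc1)c1ccc(-c2ccccc2)cc1` gives 880 nM
compound 2 `CC(C)C[C@@H](N)CN(C(=O)[C@@H]1C[C@H]1c1ccccc1)c1ccc(-c2ccccc2)cc1` gives 1.8 nM
compound 3 `N[C@H](CN(C(=O)[C@@H]1C[C@H]1c1ccccc1)c1ccc(-c2ccccc2)cc1)C1CCCCC1` gives 0.66 nM

These three share one core and differ only at the saturated chain carbon bound to an amine nitrogen. In a functional assay for agonist activity at G protein-coupled receptor 88 (Homo sapiens), read by HTRF and cAMP accumulation (on this read-out lower numbers stand for an effect already at smaller amounts and higher numbers for an effect only at larger amounts of compound), compound 1 stands highest of the three. Flipping its configuration gives a 490-fold lower number from compound 1 to compound 2 (2.69 log units; beyond the scatter), due to the fact that compounds 1 and 2 differ only in the configuration as drawn. Replacing its isobutyl gives a 1300-fold lower number from compound 1 to compound 3 (3.12 log units; beyond the scatter), while between compound 2 and compound 3 the change is a 2.7-fold lower number from compound 2 to compound 3 (0.44 log units; beyond the scatter).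

Compound 4 `CC(C)(C)[C@H](N)CN(C(=O)[C@@H]1C[C@H]1c1ccccc1)c1ccc(-c2ccccc2)cc1` keeps the configuration drawn for compound 1 and carries tert-butyl in place of isobutyl on a saturated chain carbon bound to an amine nitrogen and a saturated chain carbon. Among the compounds with values here, only the step from compound 1 to compound 3 bears on this branch, and it was large and downward; tert-butyl, like isobutyl, has no ring, so a smaller downward step is expected, a 2.9-fold lower number from compound 1 to compound 4 (0.47 log units; beyond the scatter). Compound 4 is estimated at 300 nM, between 50 nM and 3000 nM.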

Compound 4, half-maximal effective concentration: 11 nM
For compound 4 the middle estimate is 27-fold (1.44 log units) above the measured one; measured number below the stated range.
By their numbers in this assay, from the lowest: compound 3; then compound 2; then compound 4; then compound 1.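

Swapping isobutyl for tert-butyl keeps the same heavy-atom count and adds no ring, yet it gives an 80-fold lower number from compound 1 to compound 4 (1.90 log units; beyond the scatter), so at this carbon a ring is not required for a large drop. Cyclohexyl still reaches further, with a 17-fold higher number from compound 3 to compound 4 (1.22 log units; beyond the scatter). The tert-butyl compound also does not match the isobutyl compound with the lower number, with a 6.1-fold higher number from compound 2 to compound 4 (0.79 log units; beyond the scatter).

What sets these differences is not shown by any measurement here. From the compounds shown here alone, how compound 4 with its configuration flipped, or a cyclopentyl or phenyl group at this carbon, would read remains open.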